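The source may hold more compounds than are shown below. What is called first, only, known or untested is meant among the compounds shown, and "the series" means these compounds.

Two ureas sharing a common core have been examined in an assay on isolated protein for inhibition of STE20-like serine/threonine-protein kinase (Homo sapiens), read by thermal shift assay, tested at 10 uM; on this read-out higher numbers stand for stronger stabilisation of the target against heat and lower numbers for weaker stabilisation of the target. Compound 1 `Cc1ccc(F)cc1NC(=O)Nc1cc(C(C)(C)C)nn1-c1ccccc1` gives 6 degrees C in this assay. Compound 2 `CC(C)(C)c1cc(NC(=O)Nc2ccc(Cl)cc2)n(-c2ccc(S(C)(=O)=O)cc2)n1` gives 5.2 degrees C in this assay and stands at the low end of the two numbers, with a gap to compound 1 that lies within the usual scatter, so the two readings cannot be told apart. Compound 3 `CC(C)(C)c1cc(NC(=O)Nc2ccc(Cl)cc2)n(-c2ccc(NS(C)(=O)=O)cc2)n1` has not yet been measured. It differs from compound 2 in a single place: methanesulfonamido in place of methylsulfonyl on an aromatic carbon. Going by the values given here, no pair of measured compounds differs in only this way, and compound 1 and compound 2 differ from each other in several places at once, so the measured numbers offer no direct guide to what this change does. The expected step is therefore a number 0.20 degrees C lower from compound 2 to compound 3 (within the scatter), small and in no direction that would rise beyond the scatter. On that basis compound 3 is estimated to give 5 degrees C in this assay, with a likely range from 2.5 degrees C to 7.5 degrees C.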

Compound 3, shift of the target's melting temperature: 7.3 degrees C
For compound 3 the middle estimate is 2.3 degrees C below the measured one; low and high end bracket the measured number.
By their numbers in this assay, from the lowest: compounds 2 and 1 (each within the scatter of the next); then compound 3.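

In this assay, the change from methylsulfonyl to methanesulfonamido on an aromatic carbon, para to a large group, comes out as a number 2.1 degrees C higher from compound 2 to compound 3 (beyond the scatter). This single pair shows that the reading responds to what this position carries. The entering group adds a nitrogen and a hydrogen-bond donor that the leaving group lacks, and the step lies beyond the usual scatter. No measurement at hand ties the step to either of these differences.

Going by these compounds alone, with only this one pair at the position, it remains open whether the step depends on the sulfonamide arrangement as a whole or would also appear with a simple amine, a carboxylic acid or an acetamido group on the same aromatic carbon. Going by these compounds, it is also open whether the step would hold with a different aromatic group on the other side of the urea, as compound 1 differs from compound 2 there and in other places at once and so offers no test of this.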